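Three compounds at the limit and a fourth to come

The compounds below may be only part of what the source reports. "The series", "measured", "known", "first", "only" and "open" are said of these compounds alone.

compound 1, `Nc1nc(NCCNc2ncc(-c3ncc[nH]3)c(-c3ccc(C(F)(F)F)cc3)n2)ccc1[N+](=O)[O-]`: > 0.5 h in an ADME assay on microsomes from liver (Canis lupus familiaris) for metabolic stability; a higher number here means that the compound lasts longer, a lower number that the compound disappears faster
compound 2, `Nc1nc(NCCNc2ncc(-c3ncc[nH]3)c(-c3ccccc3Br)n2)ccc1[N+](=O)[O-]`: > 0.5 h
compound 3, `Nc1nc(NCCNc2ncc(-c3ncc[nH]3)c(-c3cc(F)c(F)cc3F)n2)ccc1[N+](=O)[O-]`: > 0.5 h

Compound 1 reaches only a limit of the assay in this assay, not a number. Compound 2 likewise stops at a limit. Compound 3 too gives a limit rather than a number. The steps a step that the two limits leave unreadable from compound 1 to compound 2, a step that the two limits leave unreadable from compound 1 to compound 3 and a step that the two limits leave unreadable from compound 2 to compound 3 cannot be read, because of the limit of > 0.5 h in this assay, at which 3 of the 3 values shown sit.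

Compound 4, `Nc1nc(NCCNc2ncc(-c3ncc[nH]3)c(-c3cc(F)c(Cl)cc3F)n2)ccc1[N+](=O)[O-]`, has not yet been measured in this assay. It differs from compound 1 in one place: 4-chloro-2,5-difluorophenyl in place of 4-(trifluoromethyl)phenyl on an aromatic carbon. The steps a step that the two limits leave unreadable from compound 1 to compound 2 and a step that the two limits leave unreadable from compound 1 to compound 3 change the same position and so bear on this exchange, but neither yields a size, so no direction can be expected beyond the scatter. The estimated step that the limit leaves unreadable from compound 1 to compound 4 is expected to stay hidden by the same limit. Compound 4 is estimated at 1 h, with a range from 0.5 h to 3 h.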

Compound 4, half-life: > 0.5 h
Compound 4 ended at the assay's limit (the forecaster's own chance of this, stated with the estimate: 80%); the middle value is on the limit's open side.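

Compound 4 also stops at a limit in this assay, and its steps from compound 1, compound 2 and compound 3 cannot be read because of that limit: the limit of > 0.5 h in this assay, at which 4 of the 4 values shown sit.

The compounds shown leave open how long any of the four actually lasts in this assay, and whether the exchanges on the phenyl group change that at all.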